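From 3-fluorobenzyl to 2-bromobenzyl: compound 3 to compound 4

This account rests on a few compounds, and the source may have more. Where it says the series, first, only, none or still open, it means among the compounds named here.

In a toxicity assay on NIH3T3 cells (Mus musculus) for cytotoxicity, read by resazurin assay (a higher number here means that more compound is needed for the effect, a lower number that less compound is needed), compound 3 `COC(=O)c1ccc(NCc2cncn2Cc2cccc(F)c2)cc1-c1ccccc1` stands only at a limit, > 1000 nM. Compound 1 `COC(=O)c1ccc(NCc2cncn2Cc2cccc(Br)c2)cc1-c1ccccc1` likewise gives only a limit, > 10000 nM. Compound 2 `COC(=O)c1ccc(NCc2cncn2Cc2cccc([N+](=O)[O-])c2)cc1-c1ccccc1` also gives only a limit, > 10000 nM. Compound 4 `COC(=O)c1ccc(NCc2cncn2Cc2ccccc2Br)cc1-c1ccccc1` carries 2-bromophenyl in place of 3-fluorophenyl on a saturated chain carbon bound to an aromatic nitrogen. The measured steps that bear on this, a step that the two limits leave unreadable from compound 1 to compound 3, a step that the two limits leave unreadable from compound 2 to compound 3 and a step that the two limits leave unreadable from compound 1 to compound 2, each replace one group on an aromatic carbon and yield no size to carry over, so no step beyond the scatter is expected in this assay. The expected change is a step that the limit leaves unreadable from compound 3 to compound 4. For compound 4 the estimated value is 10000 nM, within an expected range from 2000 nM to 30000 nM.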

Compound 4, half-maximal effective concentration: 10000 nM
Compound 4: the middle estimate sits on the measured number at the digits printed, and the stated range covers the measured number.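

In this assay, among these compounds, compound 4 gives the first plain number for this group on a saturated chain carbon bound to an aromatic nitrogen, 10000 nM. Compound 1, with 3-bromophenyl at that place, stands only at a limit, > 10000 nM. The change from 3-bromophenyl to 2-bromophenyl therefore reads only as a number no higher from compound 1 to compound 4 (the limit leaves the size open). Compound 2, with 3-nitrophenyl at that place, also stands only at a limit, > 10000 nM. The change from 3-nitrophenyl to 2-bromophenyl reads only as a number no higher from compound 2 to compound 4 (the limit leaves the size open). No step to compound 4 has a readable size: the limit of > 10000 nM in this assay, at which 2 of the 4 values shown sit.

Going by these compounds, the true values of compound 1, compound 2 and compound 3 remain open. So does what an amine or a carboxylic acid in place of the bromine of 2-bromobenzyl would give in this assay.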